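Swapping the Chloro-Hydroxyphenyl Arm for a Methoxyphenyl

The source may hold more compounds than are shown below. What is called first, only, known or untested is meant among the compounds shown, and "the series" means these compounds.

Of the compounds shown here, three sharing one core have been measured in a functional assay on SW-620 cells (Homo sapiens) for antiproliferative activity, read by MTT assay, with a stated time of 72 h; a higher number here means a weaker inhibitor, a lower number a stronger inhibitor. Compound 1 `COc1ccc(/C=C2\CCC/C(=C\c3cc(OC)c(OC)c(OC)c3)C2=O)cc1OC` gives 1600 nM. Compound 2 `COc1cc(/C=C2\CCC/C(=C\c3cccc(O)c3)C2=O)cc(OC)c1OC`, which carries a 3-hydroxyphenyl, reaches only the limit of > 10000 nM in this assay, so no number is known for it (the limit of > 10000 nM in this assay, at which 1 of the 3 values shown sits). Compound 3 `COc1cc(/C=C2\CCC/C(=C\c3ccc(O)c(Cl)c3)C2=O)cc(OC)c1OC`, bearing a 3-chloro-4-hydroxyphenyl, gives 800 nM, the lower of the two numbers; its step from compound 1 is a 2.0-fold lower number from compound 1 to compound 3 (0.30 log units; within the scatter), and the step from compound 2 is an at least 12-fold lower number from compound 2 to compound 3 (1.09 log units; beyond the scatter).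

Compound 4 `COc1ccccc1/C=C1\CCC/C(=C\c2cc(OC)c(OC)c(OC)c2)C1=O` has not yet been measured. It differs from compound 3 in one place: 2-methoxyphenyl in place of 3-chloro-4-hydroxyphenyl on a double-bonded chain carbon bound to a double-bonded ring carbon. The measured steps that bear on this are a 2.0-fold lower number from compound 1 to compound 3 (0.30 log units; within the scatter), where a methoxy-bearing ring without a hydrogen-bond donor sat in the same place, and an at least 6.2-fold higher number from compound 1 to compound 2 (0.79 log units; beyond the scatter). Since compound 1, which also has no hydrogen-bond donor on that ring, gave 1600 nM, a move back toward that level is expected, with a step of about a 2.5-fold higher number from compound 3 to compound 4 (0.40 log units; beyond the scatter). Compound 4 is therefore estimated at 2000 nM, within a range of 700 nM to 6000 nM.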

Compound 4, half-maximal inhibitory concentration: 2000 nM
For compound 4 middle estimate and measured number coincide at the digits printed, and the stated range covers the measured number.
By their numbers in this assay, from the lowest: compounds 3, 1 and 4 (each within the scatter of the next, the first and the last beyond it). At a limit, above all of these: compound 2.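

In this assay, the 2-methoxyphenyl, with 0 hydrogen-bond donors, stands close to the earlier groups at this place: a 2.5-fold higher number from compound 3 to compound 4 (0.40 log units; beyond the scatter) is only a modest step, while a 1.3-fold higher number from compound 1 to compound 4 (0.10 log units; within the scatter) separates it from the 3,4-dimethoxyphenyl by no more than the scatter. A hydroxy group is therefore not required for activity in the range of these numbers, as a ring with a single methoxy group still reads in that range, and the 3-chloro-4-hydroxyphenyl of compound 3 gains little over it. The step of an at least 5.0-fold lower number from compound 2 to compound 4 (0.69 log units; beyond the scatter) also shows that the 3-hydroxyphenyl of compound 2 falls behind a ring without any hydroxy group, so among these compounds having a hydroxy group does not by itself sort the numbers, and the value of compound 2 is a limit, not a number: the limit of > 10000 nM in this assay, at which 1 of the 4 values shown sits.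

The compounds shown leave open whether a 3-chlorophenyl, without the hydroxy group, would read like compound 3. They also leave open how a ring carrying an amine or a carboxylic acid would behave at this place.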